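The compounds below may be only part of what the source reports. "The series", "measured", "known", "first", "only" and "open" are said of these compounds alone.

Measured compounds:
Compound 1 `O=c1[nH]cnc2c1c(-c1ccoc1)cn2[C@@H]1O[C@H](CO)[C@@H](O)[C@H]1O`: 10300 nM
Compound 2 `Nc1nc2c(c(-c3ccoc3)cn2[C@@H]2O[C@H](CO)[C@@H](O)[C@H]2O)c(=O)[nH]1`: 14200 nM
Compound 3 `Nc1nc(N)c2c(-c3ccoc3)cn([C@@H]3O[C@H](CO)[C@@H](O)[C@H]3O)c2n1`: > 20000 nM, a limit of the assay

In a functional assay on HCT-116 cells (Homo sapiens), read by MTT assay, with a stated time of 72 h (a lower number here means a stronger inhibitor, a higher number a weaker inhibitor), compound 1 gives 10300 nM, the lowest of the two numbers shown. Compound 2 sits nearest, with a step of a 1.4-fold higher number from compound 1 to compound 2 (0.14 log units; within the scatter). For compound 3 the assay reports only a limit, (the limit of > 20000 nM in this assay, at which 1 of the 3 values shown sits).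

Compound 4 `O=c1[nH]cnc2c1c(-c1ccccc1)cn2[C@@H]1O[C@H](CO)[C@@H](O)[C@H]1O` differs from compound 1 in one place: phenyl in place of furan-3-yl on an aromatic carbon. Among the measured compounds shown here, no measured step touches this group; the single measured step concerns amino in place of hydrogen on an aromatic carbon, and it stayed within the scatter. There is therefore no measured basis for a shift in either direction in this assay, and the expectation is that compound 4 stays within the scatter of compound 1, with a step of a 1.0-fold lower number from compound 1 to compound 4 (0.01 log units; within the scatter). Compound 4 is accordingly estimated at 10000 nM, with a range from 4000 nM to 25000 nM.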

Compound 4, half-maximal inhibitory concentration: > 100000 nM
Compound 4: a limit, no number; the forecaster's own chance of this, stated with the estimate: 30%; middle value at least 10-fold (1.00 log units) away from the limit.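

In this assay, among the compounds shown here, replacing furan-3-yl with phenyl gives an at least 9.7-fold higher number from compound 1 to compound 4 (0.98 log units; beyond the scatter), whereas the one earlier step, a 1.4-fold higher number from compound 1 to compound 2 (0.14 log units; within the scatter), made at a different place on the core, stayed within the scatter. For the compounds shown here, this is the first sign that the group on this aromatic carbon, two ring bonds from the ring nitrogen, matters in this assay, and that one aromatic ring cannot simply stand in for another there. The figure for compound 4 is a limit of the assay, not a number: the limit of > 100000 nM in this assay, at which 1 of the 4 values shown sits.

Phenyl differs from furan-3-yl in both ring size and ring oxygen, so the compounds shown leave open which of these matters, and a thiophene or pyrrole ring on this carbon would help separate them. Going by these compounds, it also remains open whether phenyl has the same effect alongside the amino group of compound 2.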